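The source may hold more compounds than are shown below. What is called first, only, known or untested is meant among the compounds shown, and "the series" means these compounds.

Measured so far in an assay on CHO cells for displacement of a labelled ligand from 5-hydroxytryptamine receptor 7 (Homo sapiens); on this read-out lower numbers stand for stronger inhibition and higher numbers for weaker inhibition:
- compound 1 `CCC1(CCCCN2CCN(c3cccc(OC)c3)CC2)C(=O)Nc2ccccc21` gives 2.55 nM
- compound 2 `CCC1(CCCCN2CCN(c3ccc(OC)cc3)CC2)C(=O)Nc2ccccc21` gives 25.4 nM

Within the data shown here, compound 2 stands highest of the two numbers; the single known step, a 10-fold higher number from compound 1 to compound 2 (1.00 log units; beyond the scatter), separates it from compound 1, its nearest neighbour.

Compound 3 `CCC1(CCCCN2CCN(c3ccc(F)c(Cl)c3)CC2)C(=O)Nc2ccccc21` is not yet measured. Against compound 2 the change is 3-chloro-4-fluorophenyl in place of 4-methoxyphenyl on an amine nitrogen in a ring. Among the measured compounds shown here, no measured step matches this change: the one step known, a 10-fold higher number from compound 1 to compound 2 (1.00 log units; beyond the scatter), exchanges 3-methoxyphenyl for 4-methoxyphenyl and keeps a methoxy group, whereas here the methoxy group leaves altogether and chlorine and fluorine enter. That step does show that the group on the phenyl ring matters in this assay, so a step beyond the scatter is plausible, but its direction cannot be read from two numbers. Compound 2, which carries the 4-methoxy group, has the higher number, and compound 3 loses that group, so the estimate leans a little toward a lower number, with wide uncertainty. Compound 3 is expected at 10 nM, within a range of 2.5 nM to 40 nM, which corresponds to an expected step of a 2.5-fold lower number from compound 2 to compound 3 (0.40 log units; beyond the scatter).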

Compound 3, inhibition constant: 0.6 nM
Estimate against measurement, compound 3: 17-fold (1.22 log units) above; measured number below the stated range.
By their numbers in this assay, from the lowest: compound 3; then compound 1; then compound 2.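

In this assay, the group on the amine nitrogen in a ring has a wider effect than the exchange between the two methoxyphenyl groups could show: 3-chloro-4-fluorophenyl in place of 4-methoxyphenyl gives a 42-fold lower number from compound 2 to compound 3 (1.63 log units; beyond the scatter), and in place of 3-methoxyphenyl it gives a 4.3-fold lower number from compound 1 to compound 3 (0.63 log units; beyond the scatter). A methoxy group is therefore not required at this position for a low number, since compound 3 has no oxygen in this group and holds the lowest number of the three, with both of its steps beyond the scatter. No measurement available here explains why the halogen-bearing ring gives this result.

Chlorine and fluorine enter together, so the compounds shown do not separate their shares of the step, and a phenyl ring carrying chlorine alone, one carrying fluorine alone and an unsubstituted phenyl ring would each bear on this. Going by these compounds, it also remains open whether other groups on the ring, such as trifluoromethyl or nitrile, would give similarly low numbers, and whether this ranking holds with a different chain on the shared core.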